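Fluoro Beside the Sulfonamide: A Small Change Weighed

This account rests on a few compounds, and the source may have more. Where it says the series, first, only, none or still open, it means among the compounds named here.

In a functional assay on HEK293 cells for agonist activity at Glucose-dependent insulinotropic receptor (Homo sapiens), read by cAMP accumulation, with a stated time of 30 min (a higher number here means that more compound is needed for the effect, a lower number that less compound is needed), compound 2 `Cc1cc2c(c(Oc3cccc(NS(=O)(=O)c4ccc(Cl)cc4)c3)n1)C(=O)N(C(C)C)C2=O` gives 13 nM. Among the three measured compounds it carries the highest number, but neither neighbour is separated from it by more than the scatter: compound 1 `CCN1C(=O)c2cc(C)nc(Oc3cccc(NS(=O)(=O)c4ccc(Cl)cc4)c3)c2C1=O` gives 11 nM, and compound 3 `Cc1cc2c(c(Oc3ccc(C)c(NS(=O)(=O)c4ccc(Cl)cc4)c3)n1)C(=O)N(C(C)C)C2=O` gives 9 nM. The step of a 1.2-fold higher number from compound 1 to compound 2 (0.07 log units; within the scatter) came with methyl in place of hydrogen on a saturated chain carbon bound to an amide-type nitrogen in a ring and a saturated chain carbon; the step of a 1.4-fold lower number from compound 2 to compound 3 (0.16 log units; within the scatter) came with methyl in place of hydrogen on an aromatic carbon.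

Compound 4 `Cc1cc2c(c(Oc3cccc(NS(=O)(=O)c4ccc(Cl)cc4)c3F)n1)C(=O)N(C(C)C)C2=O` differs from compound 2 by fluoro in place of hydrogen on an aromatic carbon, the fluoro entering on an aromatic carbon of a six-membered aromatic ring of carbon only, ortho to a ((4-chlorophenyl)sulfonyl)amino group and ortho to a large group. Among the compounds with values here, only the step to compound 3, also a change of a hydrogen on an aromatic carbon, bears on this, and it stayed within the scatter; no fluoro has been tried on this ring. The step of no change at the digits printed from compound 2 to compound 4 (within the scatter) is therefore expected to stay within the scatter. For compound 4 the estimate in this assay is 13 nM, expected to fall between 5 nM and 35 nM.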

Compound 4, half-maximal effective concentration: 493 nM
For compound 4 the middle estimate is 38-fold (1.58 log units) below the measured one; measured number above the stated range.
By their numbers in this assay, from the lowest: compounds 3, 1 and 2 (each within the scatter of the next); then compound 4.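

Fluoro in place of hydrogen brought a 38-fold higher number from compound 2 to compound 4 (1.58 log units; beyond the scatter) in this assay and so shows that this aromatic carbon, ortho to a ((4-chlorophenyl)sulfonyl)amino group and ortho to a large group, is sensitive to a change of a single heavy atom. The earlier changes, with a 1.2-fold higher number from compound 1 to compound 2 (0.07 log units; within the scatter) and a 1.4-fold lower number from compound 2 to compound 3 (0.16 log units; within the scatter) as their steps, stayed within the scatter and gave no sign that one atom could move the number this far. Nothing at hand explains the size of this step.

A chloro, methoxy or hydroxyl group on the same carbon would show whether the large step belongs to fluoro or to any replacement of hydrogen there. On these data alone, it also remains open whether fluoro at this place would give a step of similar size in compound 1 or compound 3.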